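Cytotoxicity of a Methoxymethoxybenzyl Variant of Compound 2

The source may hold more compounds than are shown below. What is called first, only, known or untested is meant among the compounds shown, and "the series" means these compounds.

Compound 2 `Cc1ccc2[nH]c(=O)c(CN(CCCO)Cc3ccc(C(C)(C)C)cc3)cc2c1` carries a 3-hydroxypropyl chain on its amine nitrogen. In a toxicity assay on MDCK cells (Canis lupus familiaris) for cytotoxicity, read by crystal violet staining, with a stated time of 48 h (a lower number here means that less compound is tolerated, a higher number that more compound is tolerated), compound 2 gives > 10000 nM, which is a limit and not a number (the limit of > 10000 nM in this assay, at which 1 of the 2 values shown sits). Its neighbour compound 1 `Cc1ccc2[nH]c(=O)c(CN(Cc3ccccc3)Cc3ccc(C(C)(C)C)cc3)cc2c1` carries a benzyl group in that place. In this assay compound 1 gives > 5000 nM, likewise a limit rather than a number (the limit of > 5000 nM in this assay, at which 1 of the 2 values shown sits). The step that the two limits leave unreadable from compound 1 to compound 2 therefore cannot be read from these two values.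

Compound 3 `COCOc1ccc(CN(Cc2ccc(C(C)(C)C)cc2)Cc2cc3cc(C)ccc3[nH]c2=O)cc1` differs from compound 2 by 4-(methoxymethoxy)phenyl in place of 2-hydroxyethyl on a saturated chain carbon bound to an amine nitrogen. Going by the values given here, only the step from compound 1 to compound 2 touches this position, and it is unreadable, so no size can be taken from it. With compound 1 and compound 2 both standing at limits, compound 3 is expected to remain at or beyond a limit as well, and the step of a number no higher from compound 2 to compound 3 (the limit leaves the size open) is expected to be no step beyond the scatter. For compound 3 in this assay the estimate is 10000 nM, with a range from 3000 nM to 30000 nM.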

Compound 3, half-maximal cytotoxic concentration: 6400 nM
Compound 3: middle estimate off by 1.6-fold (0.19 log units), on the high side; the range from low to high includes it.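

In this assay, going by these compounds alone, compound 3 gives 6400 nM, the first value in this set that is a number and not a limit, so this position on the amine nitrogen can carry a group with an aromatic ring and still return a measurable value. Replacing 2-hydroxyethyl with 4-(methoxymethoxy)phenyl gives an at least 1.5-fold lower number from compound 2 to compound 3 (0.19 log units; that floor lies within the scatter), so the values show only a floor for this change and do not establish a true difference between the two compounds. Compound 1 gives only a limit, and the step from it to compound 3, which adds methoxymethoxy in place of hydrogen on an aromatic carbon, cannot be read: the limit of > 5000 nM in this assay, at which 1 of the 3 values shown sits.

As far as these compounds go, compound 2 also gives only a limit, which leaves the full size of its step open: the limit of > 10000 nM in this assay, at which 1 of the 3 values shown sits. How a chain ending in an amine or a carboxylic acid would stand in this place in this assay also remains open.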